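Swapping a pyridyl for a phenyl on a weak cytotoxic scaffold

The source may hold more compounds than are shown below. What is called first, only, known or untested is meant among the compounds shown, and "the series" means these compounds.

Compound 1 `Oc1ccc(-c2cc(-c3ccc(Cl)cc3)nc(-c3cccnc3)c2)cc1` and compound 2 `Oc1ccc(-c2cc(-c3cccnc3)nc(-c3cccc(Cl)c3)c2)cc1` share a core that carries a 4-hydroxyphenyl group together with two further aromatic rings. In a functional assay on T47D cells (Homo sapiens) for cytotoxicity, read by CCK-8 assay and cell counting, with a stated time of 2 days (a lower number here means a stronger inhibitor, a higher number a weaker inhibitor), compound 1 gives 29300 nM, the higher of the two numbers shown, and compound 2 gives 25700 nM. Within the data shown here, the single measured step, a 1.1-fold lower number from compound 1 to compound 2 (0.06 log units; within the scatter), stays within the scatter, so the two compounds cannot be told apart. Compound 3 `Oc1ccc(-c2cc(-c3ccccc3)nc(-c3ccc(Cl)cc3)c2)cc1` differs from compound 1 by phenyl in place of pyridin-3-yl on an aromatic carbon. Among the measured compounds shown here, no measured step touches this exchange: the step from compound 1 to compound 2 concerns the chlorophenyl group, not the pyridin-3-yl, and gives no direct guide. The expected step of a 1.0-fold higher number from compound 1 to compound 3 (0.01 log units; within the scatter) is therefore none beyond the scatter. Compound 3 is estimated at 30000 nM in this assay, with a range from 10000 nM to 90000 nM.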

Compound 3, half-maximal inhibitory concentration: 4270 nM
Compound 3: middle estimate off by 7.0-fold (0.85 log units), on the high side; the measured number lies below the stated range.
By their numbers in this assay, from the lowest: compound 3; then compounds 2 and 1 (each within the scatter of the next).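

In this assay, this position on the shared core, next to the ring nitrogen, responds to the exchange of pyridin-3-yl for phenyl, which gives a 6.9-fold lower number from compound 1 to compound 3 (0.84 log units; beyond the scatter). Among these compounds, the two rings are both six-membered and aromatic with the same count of heavy atoms, so the difference between them is one ring nitrogen, with its hydrogen-bond acceptor, replaced by carbon; the earlier chlorophenyl change, a 1.1-fold lower number from compound 1 to compound 2 (0.06 log units; within the scatter), gave no hint of a step this size. Nothing at hand explains why the number falls with this exchange.

From the compounds shown here alone, it remains open whether the same exchange would lower the number on the 3-chlorophenyl compound 2. Going by these compounds, it is also open how this position would respond to a phenyl ring carrying an amine or a carboxylic acid.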